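The source may hold more compounds than are shown below. What is called first, only, known or untested is meant among the compounds shown, and "the series" means these compounds.

Measured compounds in an assay on isolated protein for inhibition of mitogen-activated protein kinase kinase kinase 14 (Homo sapiens), read by ADP-Glo, with a stated time of 60 min, in the presence of a further agent that is not named here; a higher number here means a weaker inhibitor, a lower number a stronger inhibitor:

Compound 1 `COc1nsnc1C(=O)Nc1cc(C(F)(F)F)cc(C(F)(F)F)c1`: > 100000 nM
Compound 2 `Cn1nc(O)c(C(=O)Nc2cc(C(F)(F)F)cc(C(F)(F)F)c2)n1`: > 100000 nM
Compound 3 `Nc1nonc1C(=O)Nc1cc(C(F)(F)F)cc(C(F)(F)F)c1`: > 100000 nM

The value of compound 1 is a limit of the assay, not a number. The value of compound 2 is likewise a limit. The value of compound 3 is likewise a limit, so compound 3 stands nowhere in particular among the three; all sit together at the limit of > 100000 nM in this assay, at which 3 of the 3 values shown sit. The steps a step that the two limits leave unreadable from compound 1 to compound 2, a step that the two limits leave unreadable from compound 1 to compound 3 and a step that the two limits leave unreadable from compound 2 to compound 3 are accordingly unreadable in both size and direction.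

Compound 4 `O=C(Nc1cc(C(F)(F)F)cc(C(F)(F)F)c1)c1nonc1O` is not yet measured. Its difference from compound 3: hydroxy in place of amino on an aromatic carbon. Among the compounds with values here, no measured step touches this exchange, and no measured step in the set is readable at all; the only guide is the limit of > 100000 nM in this assay, at which 3 of the 3 values shown sit. The expectation is therefore that compound 4 also sits at the limit, with the step of a number no higher from compound 3 to compound 4 (the limit leaves the size open) expected not to rise beyond the scatter. For compound 4 the estimate in this assay is 100000 nM, range 30000 nM to 300000 nM, and most likely only a limit is reported again.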

Compound 4, half-maximal inhibitory concentration: > 100000 nM
Compound 4 ended at the assay's limit (the forecaster's own chance of this, stated with the estimate: 85%); the middle value lies on the limit itself.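

Compound 4, like compound 1, compound 2 and compound 3, gives a limit of the assay and not a number, so no step among these compounds can be read: the limit of > 100000 nM in this assay, at which 4 of the 4 values shown sit.

The compounds shown leave open whether any exchange on the shared core gives a measurable inhibition, and how hydroxy and amino compare once values are measurable.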